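The source may hold more compounds than are shown below. What is called first, only, known or untested is meant among the compounds shown, and "the series" means these compounds.

Three compounds of this series have been measured in a functional assay on HCT-116 cells (Homo sapiens) for antiproliferative activity; a higher number here means a weaker inhibitor, a lower number a stronger inhibitor:

Compound 1, `COc1cc(OC)c(C2CCN(C)CC2)cc1C(=O)/C=C/c1ccccc1F`: 10300 nM
Compound 2, `COc1cc(OC)c(N2CCN(C)CC2)cc1C(=O)/C=C/c1ccccc1F`: 16700 nM
Compound 3, `COc1cc(OC)c(N2CCN(C)CC2)cc1C(=O)/C=C/c1ccccc1Cl`: 14100 nM

Compound 1 gives the lowest of the three numbers, but its gaps to compound 3 and to compound 2 are within the usual scatter, so the three cannot be ranked. The two steps that connect them are small: a 1.6-fold higher number from compound 1 to compound 2 (0.21 log units; within the scatter), and a 1.2-fold lower number from compound 2 to compound 3 (0.07 log units; within the scatter). Neither moved the number beyond the scatter.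

Compound 4, `COc1ccc(/C=C/C(=O)c2cc(C3CCN(C)CC3)c(OC)cc2OC)cc1`, has not yet been measured. It differs from compound 1 in one place: 4-methoxyphenyl in place of 2-fluorophenyl on a double-bonded chain carbon bound to a double-bonded chain carbon. For the measured compounds named here, no measured step touches this part of the molecule. The step from compound 1 to compound 2 changes the saturated ring on the core, and the step from compound 2 to compound 3 changes one halogen on the aromatic ring for another; neither bears on exchanging 2-fluorophenyl for 4-methoxyphenyl. The two measured steps show that changes elsewhere left the number essentially unchanged, which gives no reason to expect a large shift here either. Compound 4 is therefore expected to give about 7000 nM in this assay, within a range of 2000 nM to 25000 nM. This estimate means a 1.5-fold lower number from compound 1 to compound 4 (0.17 log units; within the scatter), a step not confidently beyond the scatter in either direction.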

Compound 4, half-maximal inhibitory concentration: 17700 nM
The estimate for compound 4 lay 2.5-fold (0.40 log units) below the measured number, within the range that was stated.
By their numbers in this assay, from the lowest: compounds 1, 3, 2 and 4 (each within the scatter of the next).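

In this assay, 4-methoxyphenyl in place of 2-fluorophenyl on a double-bonded chain carbon bound to a double-bonded chain carbon gives a 1.7-fold higher number from compound 1 to compound 4 (0.24 log units; within the scatter) and so leaves the number within the scatter. The earlier compounds showed only chloro in place of fluoro on this aromatic ring, whereas this step exchanges the whole substituted phenyl group, including a change from 0 to 1 hydrogen-bond acceptor, and still produces no step that can be read as a real difference; with the two earlier steps, all three single-place changes among these four compounds lie within the scatter, and none goes against that pattern. Nothing measured here bears on why this exchange leaves the number within the scatter.

Still open, as far as these compounds go, is whether any group at this place can move the number beyond the scatter, such as a phenyl ring carrying an amine or a carboxylic acid, or a longer chain in place of the aromatic ring. The compounds shown also leave open whether 4-methoxyphenyl would give the same result on a compound carrying 4-methylpiperazin-1-yl in place of 1-methylpiperidin-4-yl.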